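The source may report more compounds than this note shows. Statements on the series, on what has been measured and on what is new or still open speak of the compounds shown alone.

Compound 2 `Cc1ccc(-c2nc3c(=O)[nH]c(C)nc3s2)cc1` gives the lowest number in an assay on CHO cells for displacement of a labelled ligand from adenosine receptor A3 (Homo sapiens), read by scintillation counting, with a stated time of 120 min (a higher number here means a weaker inhibitor, a lower number a stronger inhibitor), among the two measured compounds, at 33 nM. Its nearest neighbour is compound 1 `Cc1nc2sc(-c3ccccc3)nc2c(=O)[nH]1`, which in this assay gives 85 nM; the two differ only in a methyl in place of a hydrogen on an aromatic carbon, and that step amounts to a 2.6-fold lower number from compound 1 to compound 2 (0.41 log units; beyond the scatter).

Compound 3 `Cc1nc2sc(-c3ccc(F)cc3)nc2c(=O)[nH]1` has not yet been measured. It differs from compound 2 in one place: fluoro in place of methyl on an aromatic carbon. Among the measured compounds shown here, the only measured step that bears on this site is the one from compound 1 to compound 2, where adding the methyl on this aromatic carbon lowered the number modestly. A fluoro in the same place is a single heavy atom, as the methyl was, but the measured compounds give no direct reading of a fluoro here, so the size of its effect can only be bracketed between what the hydrogen and the methyl gave. Compound 3 is therefore expected to fall slightly above compound 2, by about a 1.7-fold higher number from compound 2 to compound 3 (0.22 log units; within the scatter), a shift that may not exceed the scatter. In this assay compound 3 is expected to give roughly 55 nM, within a range from 25 nM to 130 nM.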

Compound 3, inhibition constant: 107 nM
Beside the measured number, compound 3's estimate is 1.9-fold (0.29 log units) below it; the measured number falls inside the stated range.
By their numbers in this assay, from the lowest: compound 2; then compounds 1 and 3 (each within the scatter of the next).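

In this assay, the aromatic carbon para to a large group proves sensitive to which single heavy atom it carries: fluoro in place of methyl reverses the gain seen with methyl (a 3.2-fold higher number from compound 2 to compound 3 (0.51 log units; beyond the scatter)), so a group of one heavy atom at this position does not by itself give the lower number. Fluoro in place of hydrogen gives no change that can be read (a 1.3-fold higher number from compound 1 to compound 3 (0.10 log units; within the scatter)), so compound 1 and compound 3 cannot be told apart, and among the three groups shown here only the methyl of compound 2 stands apart from the others. The data offered here give no explanation of why methyl and fluoro part ways at this carbon.

The compounds shown leave open whether the lower number belongs to methyl alone or would carry over to an ethyl, a methoxy or a chlorine at the same carbon. They also leave open whether a methyl on another carbon of this six-membered ring would act as it does here, and whether the step would hold on a core bearing a longer chain in place of its own methyl.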